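Naphthalen-2-yl to naphthalen-1-yl in compound 3

The source may hold more compounds than are shown below. What is called first, only, known or untested is meant among the compounds shown, and "the series" means these compounds.

In a functional assay on WM 266-4 cells (Homo sapiens) for antiproliferative activity, read by MTT assay, with a stated time of 24 h (a lower number here means a stronger inhibitor of growth, a higher number a weaker inhibitor of growth), compound 3 `c1ccc(N2N=C(c3ccc4c(c3)OCCO4)CC2c2ccc3ccccc3c2)cc1` gives 13900 nM as the higher of two exact numbers. Compound 2 `c1ccc(COc2cccc(C3CC(c4ccc5c(c4)OCCO5)=NN3c3ccccc3)c2)cc1` gives 870 nM as the lower one. Compound 1 `c1ccc(N2N=C(c3ccc4c(c3)OCCO4)CC2c2ccco2)cc1` gives > 100000 nM as a limit of the assay.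

For the measured compounds named here, compound 4 `c1ccc(N2N=C(c3ccc4c(c3)OCCO4)CC2c2cccc3ccccc23)cc1` carries naphthalen-1-yl in place of naphthalen-2-yl on a saturated ring carbon as its single change. Going by the values given here, the only measured step at this carbon is an at least 7.1-fold lower number from compound 1 to compound 3 (0.85 log units; beyond the scatter) with naphthalen-2-yl in place of furan-2-yl. That swap changed the group far more than this one does, so a much smaller step is expected in this assay with no clear direction. The expected step is a 1.1-fold higher number from compound 3 to compound 4 (0.03 log units; within the scatter) and lies within the scatter. For compound 4 the estimate is 15000 nM with an expected range of 3500 nM to 70000 nM in this measurement.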

Compound 4, concentration for 50% growth inhibition: > 100000 nM
Compound 4 was reported as a limit; the forecaster's own chance of this, stated with the estimate: 10%; middle value at least 6.6-fold (0.82 log units) from the limit.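

Replacing naphthalen-2-yl with naphthalen-1-yl on this saturated ring carbon joins the same atoms differently, yet in this assay it gives an at least 7.1-fold higher number from compound 3 to compound 4 (0.85 log units; beyond the scatter), so the point of attachment alone can weaken growth inhibition here. On these data alone, compound 4 sits at a limit of the assay, so the full size of this step is unknown. The step between compound 1 and compound 4 cannot be read because both sit at that limit: the limit of > 100000 nM in this assay, at which 2 of the 4 values shown sit.

Left open is how a phenyl group bearing an amine or a carboxylic acid at this carbon would compare with naphthalen-2-yl.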